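Hydroxy in place of nitro on the anilino ring

The source may report more compounds than this note shows. Statements on the series, on what has been measured and on what is new or still open speak of the compounds shown alone.

Compound 1 `CCn1nc(-c2ccnc(Nc3ccc([N+](=O)[O-])cc3)n2)c2ccccc21`: 24000 nM
Compound 2 `CCn1nc(-c2ccnc(Nc3cccc([N+](=O)[O-])c3)n2)c2ccccc21`: 2310 nM

Among the compounds with values here, in a functional assay on MCF7 cells (Homo sapiens) for antiproliferative activity, read by MTT assay, with a stated time of 72 h (on this read-out lower numbers stand for stronger inhibition of growth and higher numbers for weaker inhibition of growth), compound 2 gives 2310 nM, the lowest of the two numbers; its only neighbour, compound 1, gives 24000 nM. Within the data shown here, the one measured step, a 10-fold lower number from compound 1 to compound 2 (1.02 log units; beyond the scatter), changes where the nitro group sits and says nothing about replacing it. Compound 3 `CCn1nc(-c2ccnc(Nc3cccc(O)c3)n2)c2ccccc21` differs from compound 2 by hydroxy in place of nitro on an aromatic carbon. Among the measured compounds shown here, no measured step bears on this change, so no step beyond the scatter is expected, a 1.1-fold higher number from compound 2 to compound 3 (0.03 log units; within the scatter), with wide uncertainty. Compound 3 is therefore estimated at 2500 nM, in a range from 600 nM to 10000 nM.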

Compound 3, concentration for 50% growth inhibition: 33500 nM
Compound 3: the middle estimate sits 13-fold (1.13 log units) below what was measured, and the stated range ends below it.
By their numbers in this assay, from the lowest: compound 2; then compounds 1 and 3 (each within the scatter of the next).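

In this assay, the nitro group itself counts at this position, not only where it sits: hydroxy in place of nitro gives a 15-fold higher number from compound 2 to compound 3 (1.16 log units; beyond the scatter), so the standing of 3-nitrophenyl does not carry over to 3-hydroxyphenyl. The other new step, a 1.4-fold higher number from compound 1 to compound 3 (0.14 log units; within the scatter), leaves 3-nitrophenyl as the only one of the three anilino groups that stands apart. Nothing shown here accounts for this difference.

As far as these compounds go, whether an amine, a nitrile or a methoxy group in this place would follow nitro or hydroxy remains open.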